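The source may hold more compounds than are shown below. What is called first, only, known or untested is meant among the compounds shown, and "the series" means these compounds.

In a functional assay on L1210 cells (Mus musculus) for antiproliferative activity, read by cell counting, with a stated time of 2 days (on this read-out lower numbers stand for stronger inhibition and higher numbers for weaker inhibition), compound 1 `COc1ccc(C(=O)c2sc(Nc3ccccc3)nc2N)cc1OC` gives > 10000 nM, which is a limit of the assay. Within the data shown here, compound 2 `COc1ccc(Nc2nc(N)c(C(=O)c3ccc(OC)c(OC)c3)s2)cc1` gives 38 nM, the only actual number so far. Compound 3 `COc1ccc(Nc2nc(N)c(C(=O)c3cc(OC)c(OC)c(OC)c3)s2)cc1` differs from compound 2 by methoxy in place of hydrogen on an aromatic carbon. Among the measured compounds shown here, the one measured step of the same kind, an at least 260-fold lower number from compound 1 to compound 2 (2.42 log units; beyond the scatter), is large, but it lies elsewhere in the molecule and rests on (the limit of > 10000 nM in this assay, at which 1 of the 2 values shown sits), so it offers only weak guidance. In this assay a small move to a lower number is expected, possibly none beyond the scatter, with an expected 1.9-fold lower number from compound 2 to compound 3 (0.28 log units; within the scatter). Compound 3 is estimated at 20 nM, with an expected range of 4 nM to 100 nM.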

Compound 3, half-maximal inhibitory concentration: 1500 nM
Beside the measured number, compound 3's estimate is 75-fold (1.88 log units) below it; the whole stated range lies below it.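

In this assay methoxy in place of hydrogen at this position, ortho to a methoxy group and meta to a large group, gives a 39-fold higher number from compound 2 to compound 3 (1.60 log units; beyond the scatter) and so shows that this place tolerates the change poorly. The same kind of change elsewhere in the molecule, with an at least 260-fold lower number from compound 1 to compound 2 (2.42 log units; beyond the scatter) resting on a limit of the assay, goes the other way, so the direction of this change depends on where it is made.

Going by these compounds, whether fluorine, hydroxy or ethoxy at this position would keep the number near that of compound 2 stays open. Nothing in the data shown accounts for the rise.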